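A few compounds are considered here, and "the series" means these few. Any claim that something is new, unique, unknown or untested is made for them only; others in the source may bear on it.

Compound 1 (`c1ccc(Cn2ccc3nc(-c4ccccc4)nc-3c2)cc1`) is the reference point in an ADME assay on MDBK cells (Bos taurus) for cytotoxicity; on this read-out higher numbers stand for lower toxicity in this test and lower numbers for higher toxicity in this test. In this assay, compound 1 gives > 100000 nM, and this is a limit of the assay, not a measured number. Compound 2 (`FC(F)(F)c1cccc(Cn2ccc3nc(-c4ccccc4)nc-3c2)c1`) carries trifluoromethyl in place of hydrogen on an aromatic carbon, and in this assay compound 2 gives 98000 nM.

Among the compounds with values here, this is the only measured step that bears on the new change, and it is recorded as an at least 1.0-fold lower number from compound 1 to compound 2 (0.00 log units; that floor lies within the scatter). On these data alone, its true size stays open since it starts from the limit of > 100000 nM in this assay, at which 1 of the 2 values shown sits.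

Compound 3 (`CC(C)(C)c1ccc(Cn2ccc3nc(-c4ccccc4)nc-3c2)cc1`) differs from compound 1 in a related way, with tert-butyl in place of hydrogen on an aromatic carbon. Both changes add a group to the same benzyl-bearing side of the molecule, though one example is thin support. Going by compound 2 and its step of an at least 1.0-fold lower number from compound 1 to compound 2 (0.00 log units; that floor lies within the scatter), only a small move toward lower numbers is expected in this assay, possibly none beyond the scatter.

The expected step is an at least 1.4-fold lower number from compound 1 to compound 3 (0.15 log units; that floor lies within the scatter).

For compound 3, the estimated value is 70000 nM, with an expected range from 30000 nM to 100000 nM.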

Compound 3, half-maximal cytotoxic concentration: 22000 nM
Estimate against measurement, compound 3: 3.2-fold (0.50 log units) above, and the stated range ends above it.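

In this assay, placing tert-butyl on an aromatic carbon of the six-membered carbon-only ring, para to a large group, gives an at least 4.5-fold lower number from compound 1 to compound 3 (0.65 log units; beyond the scatter). This shows that a change on this ring can clearly move the read-out toward higher toxicity in this test, which the earlier step could not show, as it was recorded only as an at least 1.0-fold lower number from compound 1 to compound 2 (0.00 log units; that floor lies within the scatter). The size of the new step is still only a floor, and its full size stays open for this reason: the limit of > 100000 nM in this assay, at which 1 of the 3 values shown sits.

Compound 2 and compound 3 differ from each other in more than one place, so the compounds shown cannot tell whether the clearer step belongs to tert-butyl itself, to its place on the ring, or to both. On these data alone, it also stays open how the read-out would respond if an amine, a carboxylic acid, or a longer carbon chain stood on the same aromatic carbon in place of tert-butyl, and whether any such group would leave the number as high as in compound 1.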